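The source may hold more compounds than are shown below. What is called first, only, known or untested is meant among the compounds shown, and "the series" means these compounds.

Measured so far:
- compound 1, `CCCCc1nc(C(=O)OC)nn1-c1ccc(F)cc1`: 6400 nM
- compound 2, `COC(=O)c1nc(C2CCCC2)n(-c2ccc(F)cc2)n1`: 70500 nM

In a functional assay on NCI-H226 cells (Homo sapiens) for inhibition, read by MTT assay, with a stated time of 72 h (a higher number here means a weaker inhibitor of growth, a lower number a stronger inhibitor of growth), compound 1 gives 6400 nM. Within the data shown here, compound 2 is the weaker growth inhibitor of the two, at 70500 nM in this assay, the highest number among the two measured, and the one single measured step, an 11-fold higher number from compound 1 to compound 2 (1.04 log units; beyond the scatter), is large and beyond the scatter.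

Compound 3, `COC(=O)c1nc(C2CCCCC2)n(-c2ccc(F)cc2)n1`, has not been measured. The change from compound 2 to compound 3 is cyclohexyl in place of cyclopentyl on an aromatic carbon. Among the measured compounds shown here, no measured step involves this exact change; the only step on record concerns a chain replaced by a ring at the same aromatic carbon, so it bears on compound 3 only indirectly. That step was large and went towards a weaker inhibitor. Enlarging the ring by one carbon is a smaller change than exchanging a chain for a ring, so the expected step is small, with direction uncertain. The estimate for compound 3 is 80000 nM, range 25000 nM to 250000 nM, meaning an expected step of a 1.1-fold higher number from compound 2 to compound 3 (0.05 log units; within the scatter) from compound 2.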

Compound 3, concentration for 50% growth inhibition: 6260 nM
For compound 3 the middle estimate is 13-fold (1.11 log units) above the measured one, outside the stated range (below it).
By their numbers in this assay, from the lowest: compounds 3 and 1 (each within the scatter of the next); then compound 2.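

In this assay, this position, on an aromatic carbon between two ring nitrogen atoms, separates two closely related carbon rings sharply: cyclohexyl in place of cyclopentyl gives a large change (an 11-fold lower number from compound 2 to compound 3 (1.05 log units; beyond the scatter)), which a comparison of chain and ring alone could not show. Cyclohexyl in place of butyl leaves the two compounds within the scatter (a 1.0-fold lower number from compound 1 to compound 3 (0.01 log units; within the scatter)), so the large change seen earlier (an 11-fold higher number from compound 1 to compound 2 (1.04 log units; beyond the scatter)) does not hold for rings in general: compound 3 goes against that reading, and among the three compounds only compound 2, with cyclopentyl, stands apart. No measurement shown here offers an explanation for the difference between the five-membered and six-membered rings.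

Open, as far as these compounds go, is whether cyclopentyl is an isolated low point at this position or part of a wider trend, which cyclobutyl, cycloheptyl, a branched chain such as isopropyl or a longer chain such as hexyl could help settle. Also open, from the compounds shown here alone, is whether the same ranking of cyclopentyl, cyclohexyl and butyl persists when the methoxycarbonyl group gives way to a carboxylic acid or an amide, or when an amine is carried on the ring at this position.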